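The compounds below may be only part of what the source reports. "The series", "measured", "known", "first", "only" and "open" are said of these compounds alone.

Three compounds have been measured so far in a functional assay on A-431 cells (Homo sapiens) for inhibition, read by MTT assay, with a stated time of 72 h; on this read-out lower numbers stand for stronger inhibition and higher numbers for weaker inhibition:

- Compound 1 `O=[N+]([O-])c1ccc(-c2nnc(SCCCN3CCN(c4nc5ccccc5o4)CC3)o2)cc1` gives 46900 nM
- Compound 2 `Oc1ccc(-c2nnc(SCCCN3CCN(c4nc5ccccc5o4)CC3)o2)cc1` gives 117000 nM
- Compound 3 `O=[N+]([O-])c1ccc(-c2nnc(SCCCN3CCN(c4nc5ccccc5s4)CC3)o2)cc1` gives 46500 nM

Compound 3 and compound 1 lie within the usual scatter of each other, while compound 2 shows a clearly higher number than either. Compound 4 `Fc1ccc(-c2nnc(SCCCN3CCN(c4nc5ccccc5s4)CC3)o2)cc1` is still unmeasured. It keeps the whole of compound 3 except for one change, fluoro in place of nitro on an aromatic carbon.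

Among the compounds with values here, two measured steps bear on this. Within the data shown here, replacing the same nitro group with hydroxy gave a 2.5-fold higher number from compound 1 to compound 2 (0.40 log units; beyond the scatter), the only measured swap at that spot. Exchanging the group on the ring amine nitrogen gave a 1.0-fold lower number from compound 1 to compound 3 (0.00 log units; within the scatter), so a nitro swap may well behave similarly in compound 3. Fluoro itself has not been tested here, which makes this a rough guide. A small rise is expected, and the estimated step is a 1.3-fold higher number from compound 3 to compound 4 (0.11 log units; within the scatter), probably not beyond the scatter. For compound 4 the expected value is 60000 nM, with an estimated range from 25000 nM to 130000 nM.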

Compound 4, half-maximal inhibitory concentration: 67000 nM
Estimate against measurement, compound 4: 1.1-fold (0.05 log units) below; the range from low to high includes it.
By their numbers in this assay, from the lowest: compounds 3, 1, 4 and 2 (each within the scatter of the next, the first and the last beyond it).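

Going from 4-nitrophenyl to 4-fluorophenyl in this assay gives a 1.4-fold higher number from compound 3 to compound 4 (0.16 log units; within the scatter), so at this position the nitro group, with its three heavy atoms and its hydrogen-bond acceptors, can give way to a single fluorine without a step that stands out from the scatter. Within the data shown here, the only earlier swap here, hydroxy, gave a 2.5-fold higher number from compound 1 to compound 2 (0.40 log units; beyond the scatter) and lay beyond the scatter, so the two replacements read differently, although they start from different compounds. No measurement here gives a reason for either step.

Still open, as far as these compounds go, is how an amine, a carboxylic acid or a methoxy group would fare at this spot. From the compounds shown here alone, it is also open whether fluoro would behave the same way with 1,3-benzoxazol-2-yl on the ring amine nitrogen or with a longer chain.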